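The compounds below may be only part of what the source reports. "The series", "measured", "known", "first", "only" and "open" are said of these compounds alone.

Measured so far in a functional assay on KB cells (Homo sapiens) for antiproliferative activity, read by sulforhodamine B assay, with a stated time of 3 days; a higher number here means a weaker inhibitor of growth, a lower number a stronger inhibitor of growth

- Compound 1 `O=C(Nc1ccccn1)c1cccc(Nc2ncc(F)c(Nc3ccc(F)cc3)n2)c1` gives 20000 nM
- Compound 2 `O=C(Nc1cccc(Nc2ncc(F)c(Nc3ccc(F)cc3)n2)c1)c1cnccn1` gives 23600 nM
- Compound 3 `O=C(Nc1cccc(Nc2ncc(F)c(Nc3ccc(F)cc3)n2)c1)c1ccccc1` gives > 10000 nM

The entry for compound 3 at > 10000 nM is a limit of the assay and not a number. Compound 4 `O=C(Nc1cc(Cl)cc(Cl)c1)c1cccc(Nc2ncc(F)c(Nc3ccc(F)cc3)n2)c1` differs from it by carrying (3,5-dichlorophenyl)carbamoyl in place of benzamido on an aromatic carbon and nothing else in the molecule changes.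

Two measured steps reach compound 3 and neither gives a size. These are a step that the limit leaves unreadable from compound 1 to compound 3 and a step that the limit leaves unreadable from compound 2 to compound 3 and both are unreadable because of the limit of > 10000 nM in this assay, at which 1 of the 3 values shown sits, in this small set. Among the compounds with values here, the only readable step is a 1.2-fold higher number from compound 1 to compound 2 (0.07 log units; within the scatter) and it offers no sign of a large move. Resting on that step, no change beyond the scatter is expected in this assay in either direction, although the dichlorophenyl group has no measured precedent here and the range must stay wide.

The expected step is a number no higher from compound 3 to compound 4 (the limit leaves the size open) in this estimate. For compound 4 the estimated value is 10000 nM with an expected range from 3000 nM to 30000 nM as its limits.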

Compound 4, concentration for 50% growth inhibition: 20100 nM
Estimate against measurement, compound 4: 2.0-fold (0.30 log units) below, within the range that was stated.
By their numbers in this assay, from the lowest: compounds 1, 4 and 2 (each within the scatter of the next).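

In this assay, 3,5-dichlorophenyl on the amide-type nitrogen in place of pyridin-2-yl gives a 1.0-fold higher number from compound 1 to compound 4 (0.00 log units; within the scatter), so at this position a ring of carbon only, bearing two chlorines, gives a number that stays within the scatter of the nitrogen-containing ring of compound 1. Set against ((pyrazin-2-yl)carbonyl)amino, the (3,5-dichlorophenyl)carbamoyl group likewise gives a 1.2-fold lower number from compound 2 to compound 4 (0.07 log units; within the scatter), which means that all three compounds with exact values now sit within the scatter of one another. The value of compound 3 remains a limit and not a number, so the step from it to compound 4 cannot be read: the limit of > 10000 nM in this assay, at which 1 of the 4 values shown sits.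

Going by these compounds, it remains open whether a carboxylic acid or a piperazine amine on this aromatic carbon would move the number beyond the scatter. On these data alone, whether a single chlorine on the ring would do so also remains open.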